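A 3-Nitrophenoxy Swap on Compound 2

The source may hold more compounds than are shown below. What is called first, only, known or untested is meant among the compounds shown, and "the series" means these compounds.

In a functional assay on PC-3 cells (Homo sapiens) for inhibition, read by sulforhodamine B assay, with a stated time of 48 h, tested at 50 uM (on this read-out lower numbers stand for less inhibition of growth and higher numbers for more inhibition of growth at the one concentration tested), compound 1 `COc1ccc([C@@H]2C/C(=N/OCc3cn(-c4ccc(O)cc4)nn3)c3cc(CC=C(C)C)c(OC)cc3O2)cc1` gives 64% and compound 2 `COc1ccc([C@@H]2CC(=O)c3cc(CC=C(C)C)c(OC)cc3O2)cc1` gives 58%, so compound 2 stands within the scatter of compound 1. Compound 3 `COc1cc2c(cc1CC=C(C)C)C(=O)C[C@@H](c1ccc(Oc3cccc([N+](=O)[O-])c3)cc1)O2` has 3-nitrophenyl in place of methyl on an oxygen on an aromatic ring. No measured step sizes this change. Going by the values given here, the only guide, differing from compound 2 elsewhere, is compound 1, which gives 64%. A small upward move, none beyond the scatter, is therefore expected in this assay, an estimated a number 4 percentage points higher from compound 2 to compound 3 (within the scatter). The expected value for compound 3 is 62%, within an estimated range of 42% to 80%.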

Compound 3, percent growth inhibition at one concentration: 21%
Beside the measured number, compound 3's estimate is 41 percentage points above it; the measured number lies below the stated range.
By their numbers in this assay, from the lowest: compound 3; then compounds 2 and 1 (each within the scatter of the next).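

In this assay the change from methoxy to 3-nitrophenoxy gives a number 37 percentage points lower from compound 2 to compound 3 (beyond the scatter) as the first step read at this place. Compounds 1 and 2 carry the same methoxy there, so only now is it seen that growth inhibition at the one concentration tested depends on the group on this oxygen. Nothing measured here accounts for the fall.

From the compounds shown here alone, whether the fall comes from the added ring or from the nitro group stays open, and a plain phenoxy would separate the two. A hydroxyl on this oxygen would show whether the methyl itself matters.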